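Moving the Fluorine on the Ring-Nitrogen Phenyl

This account rests on a few compounds, and the source may have more. Where it says the series, first, only, none or still open, it means among the compounds named here.

Compound 1 `CCN1CCN(c2c(CO)c(=O)oc3ccccc23)CC1` gives > 50000 nM in a toxicity assay on HEK-293T cells (Homo sapiens) for inhibition, read by MTT assay, with a stated time of 24 h (on this read-out lower numbers stand for higher toxicity in this test and higher numbers for lower toxicity in this test), a limit of the assay.
Compound 2 `O=c1oc2ccccc2c(N2CCN(c3ccccc3)CC2)c1CO` gives > 50000 nM in this assay, also a limit.
Compound 3 `O=c1oc2ccccc2c(N2CCN(c3ccc(F)cc3)CC2)c1CO` gives > 50000 nM in this assay, again a limit.

Compound 3 thus stands where every measured compound stands: the limit of > 50000 nM in this assay, at which 3 of the 3 values shown sit. Compound 4 `O=c1oc2ccccc2c(N2CCN(c3ccccc3F)CC2)c1CO` is not yet measured; it differs from compound 3 by 2-fluorophenyl in place of 4-fluorophenyl on an amine nitrogen in a ring. The steps nearest to this change are a step that the two limits leave unreadable from compound 1 to compound 3 and a step that the two limits leave unreadable from compound 2 to compound 3, and both were left unreadable by the limits at which their ends sit; a step that the two limits leave unreadable from compound 1 to compound 2 is no more readable. Nothing measured therefore points to a step of any size in this assay. Compound 4 is expected to give 80000 nM (range 35000 nM to 200000 nM), most likely again as a limit, which would mean an expected step that the limit leaves unreadable from compound 3 to compound 4.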

Compound 4, half-maximal cytotoxic concentration: > 50000 nM
Compound 4 was reported as a limit; the forecaster's own chance of this, stated with the estimate: 85%; the middle value does not contradict the limit.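

The steps from compound 1, compound 2 and compound 3 to compound 4 cannot be read, since each pair ends in a limit: the limit of > 50000 nM in this assay, at which 4 of the 4 values shown sit. The compounds shown leave open how toxic any of them is in this assay, and whether 2-fluorophenyl and 4-fluorophenyl differ there at all.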